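A few compounds are considered here, and "the series" means these few. Any claim that something is new, unique, unknown or untested is made for them only; others in the source may bear on it.

The three measured compounds in a functional assay on MCF7 cells (Homo sapiens) for antiproliferative activity, read by MTT assay, with a stated time of 24 h; on this read-out higher numbers stand for weaker inhibition and lower numbers for stronger inhibition:

compound 1 `CCCCc1oc2ccccc2c1C(=O)c1ccc(OCC(=O)NC(C)C)cc1` gives > 50000 nM
compound 2 `CCCCc1oc2ccccc2c1C(=O)c1ccc(OCC(=O)Nc2ccccc2)cc1` gives 33600 nM
compound 3 `CCCCc1oc2ccccc2c1C(=O)c1ccc(OCC(=O)NCc2ccccc2)cc1` gives 19600 nM

The value of compound 1 is a limit of the assay and not a number, as shown by the limit of > 50000 nM in this assay, at which 1 of the 3 values shown sits. Compound 1 therefore stands only as the weakest end of the small set, without a number of its own.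

Compound 4 `CCCCc1oc2ccccc2c1C(=O)c1ccc(OCCCC(=O)N2CCCCC2)cc1` differs from compound 1 in one place: 2-((piperidin-1-yl)carbonyl)ethyl in place of isopropylcarbamoyl on a saturated chain carbon bound to an oxygen on an aromatic ring. Two measured steps start from compound 1 and also alter the amide-type nitrogen: an at least 1.4-fold lower number from compound 1 to compound 2 (0.17 log units; that floor lies within the scatter) and an at least 2.5-fold lower number from compound 1 to compound 3 (0.40 log units; beyond the scatter). Both replace the isopropyl with an aromatic group and both lower the number, the second beyond the scatter. The change to compound 4 is of another kind: the chain between the aromatic oxygen and the carbonyl grows longer, and the nitrogen becomes part of a six-membered non-aromatic ring with no hydrogen-bond donor. Going by the values given here, no measured step covers such a change, so only the direction seen for compound 2 and compound 3 is carried over. A lowering of modest size is expected, with wide uncertainty. For compound 4 in this assay the estimate is 30000 nM, between 10000 nM and 60000 nM, which would mean an expected step of an at least 1.6-fold lower number from compound 1 to compound 4 (0.22 log units; that floor lies within the scatter).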

Compound 4, half-maximal inhibitory concentration: 33000 nM
Compound 4: middle estimate off by 1.1-fold (0.04 log units), on the low side, within the range that was stated.
By their numbers in this assay, from the lowest: compounds 3, 4 and 2 (each within the scatter of the next). At a limit, above all of these: compound 1.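

Compound 1 stands in this assay only at a limit, not at a number: the limit of > 50000 nM in this assay, at which 1 of the 4 values shown sits. Against that limit, the change to the longer chain ending in a piperidine amide gives an at least 1.5-fold lower number from compound 1 to compound 4 (0.18 log units; that floor lies within the scatter), so this change brings no step that can be told from the scatter. The new group has no aromatic ring and 0 hydrogen-bond donors, yet the comparisons with the aromatic amides show a 1.7-fold higher number from compound 3 to compound 4 (0.23 log units; within the scatter) and a 1.0-fold lower number from compound 2 to compound 4 (0.01 log units; within the scatter), so among these compounds neither an aromatic group on the amide nitrogen nor the amide hydrogen is needed to reach this level.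

From the compounds shown here alone, compound 4 alters the chain length and the nitrogen group in a single step, so the share of each stays unknown, and a piperidine amide on the shorter chain of compound 1 would pull the two apart. Also open, going by these compounds, is how a morpholine amide or a free carboxylic acid would read in this place, and whether any group here can bring the number far lower.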